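Bromine in place of hydrogen on the pendant phenyl ring

The source may hold more compounds than are shown below. What is called first, only, known or untested is meant among the compounds shown, and "the series" means these compounds.

Measured compounds:
compound 1 `Cc1cc(O)c(C(=O)/C=C/c2ccc(Br)cc2)c(-c2ccccc2)c1C(=O)/C=C/c1ccc(Br)cc1`: 33500 nM
compound 2 `Cc1cc(O)c(C(=O)/C=C/c2ccc(Cl)cc2)c(-c2ccc(Cl)cc2)c1C(=O)/C=C/c1ccc(Cl)cc1`: "not active" (no number reported) (no number reported)
compound 3 `Cc1cc(O)c(C(=O)/C=C/c2ccc(OCc3ccccc3)cc2)c(-c2ccccc2)c1C(=O)/C=C/c1ccc(OCc2ccccc2)cc1`: 20000 nM

In a functional assay on HeLa cells (Homo sapiens) for cytotoxicity, read by MTT assay, with a stated time of 24 h (a lower number here means a stronger inhibitor, a higher number a weaker inhibitor), compound 1 gives 33500 nM, the higher of the two numbers reported. Compound 3 gives 20000 nM in this assay, which sits within the scatter of the number for compound 1, so no order between these two can be claimed. Compound 2, the fully chlorinated analogue, is reported in this assay as "not active" (no number reported), with no number attached.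

Compound 4 `Cc1cc(O)c(C(=O)/C=C/c2ccc(Br)cc2)c(-c2ccc(Br)cc2)c1C(=O)/C=C/c1ccc(Br)cc1` has not yet been measured in this assay. It differs from compound 1 by bromo in place of hydrogen on an aromatic carbon. Going by the values given here, no measured pair in this set shows this exact change, so its size is unknown. Compound 4 shares its three-halogen pattern with compound 2, and because compound 2 is reported as "not active" (no number reported) the step is expected to run toward a weaker inhibitor, plausibly beyond the scatter, with a real chance that no number at all is obtained. The estimated step of a 1.8-fold higher number from compound 1 to compound 4 (0.25 log units; within the scatter) reflects this expectation. Compound 4 is therefore expected to give about 60000 nM, within a range of 25000 nM to 150000 nM.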

Compound 4, half-maximal inhibitory concentration: 30000 nM
For compound 4 the middle estimate is 2.0-fold (0.30 log units) above the measured one; measured number inside the range.
By their numbers in this assay, from the lowest: compounds 3, 4 and 1 (each within the scatter of the next).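

Bromo in place of hydrogen on an aromatic carbon, para to a large group, gives a 1.1-fold lower number from compound 1 to compound 4 (0.05 log units; within the scatter) in this assay, so this position can carry a bromine atom with no shift that can be told from the usual scatter. Going by these compounds alone, this is the only step in the set that can be read in one place, and it holds with compound 4 keeping a number. Compound 2 differs from compound 4 in more than one place, so its lack of a number cannot be set against this step, and nothing at hand gives a reason for the result.

The compounds shown leave open how an amine, a methoxy group or a carboxylic acid at this position would read. They also leave open whether chloro here would read as bromo does.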